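Working notes: trifluoromethyl for chloro on the urea aryl

A few compounds are considered here, and "the series" means these few. Any claim that something is new, unique, unknown or untested is made for them only; others in the source may bear on it.

In a functional assay on CCRF-CEM cells (Homo sapiens) for inhibition, read by sulforhodamine B assay, with a stated time of 48 h (a lower number here means a stronger inhibitor of growth, a higher number a weaker inhibitor of growth), compound 2 `O=C(Nc1cccc(-n2cc(-c3ccncc3)c(-c3ccc(Cl)c(O)c3)n2)c1)Nc1ccc(Cl)c(Cl)c1` gives 1030 nM. Among the three numbers in hand this is the second highest. Compound 1 `COc1cc(-c2nn(-c3cccc(NC(=O)Nc4ccc(Cl)c(Cl)c4)c3)cc2-c2ccncc2)ccc1Cl` gives 1040 nM in this assay, and the step of a 1.0-fold lower number from compound 1 to compound 2 (0.00 log units; within the scatter) leaves the two standing together. Compound 3 `COc1cc(-c2nn(-c3cccc(NC(=O)c4ccccc4)c3)cc2-c2ccncc2)ccc1Cl` gives 492 nM, and the step of a 2.1-fold lower number from compound 1 to compound 3 (0.33 log units; beyond the scatter) is the only one here that clears the scatter.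

Compound 4 `O=C(Nc1cccc(-n2cc(-c3ccncc3)c(-c3ccc(Cl)c(O)c3)n2)c1)Nc1ccc(Cl)c(C(F)(F)F)c1` differs from compound 2 in one place: trifluoromethyl in place of chloro on an aromatic carbon. Among the measured compounds shown here, no measured pair shows this exchange. The step that bears on the same end of the molecule is a 2.1-fold lower number from compound 1 to compound 3 (0.33 log units; beyond the scatter), where the whole (3,4-dichlorophenyl)amino gave way to phenyl and the number moved only modestly. The other measured step, at the far end of the molecule, stayed within the scatter. The present change is narrower than either, a single substituent on the terminal aryl, so no step beyond the scatter is expected in this assay, in either direction.

Compound 4 is therefore expected to give 1000 nM, with a range from 400 nM to 2500 nM. The expected step is a 1.0-fold lower number from compound 2 to compound 4 (0.01 log units; within the scatter).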

Compound 4, concentration for 50% growth inhibition: 719 nM
Estimate against measurement, compound 4: 1.4-fold (0.14 log units) above, within the range that was stated.
By their numbers in this assay, from the lowest: compounds 3, 4, 2 and 1 (each within the scatter of the next, the first and the last beyond it).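

The aromatic carbon ortho to a chloro group on the terminal aryl of the urea accepts trifluoromethyl, with 4 heavy atoms entering where chloro's 1 heavy atom leaves, and in this assay the change stays within the scatter (a 1.4-fold lower number from compound 2 to compound 4 (0.16 log units; within the scatter)). Among the compounds shown here, the earlier step at this end of the molecule replaced the whole (3,4-dichlorophenyl)amino, so this is the first reading of a single substituent on that aryl, with the urea and the rest of the molecule left unchanged. Nothing measured on these compounds bears on why this step has the size it has.

Only chloro and trifluoromethyl are shown at this carbon, so it remains open whether a group of another kind there, such as an amine, a carboxylic acid or a longer alkyl chain, would also stay within the scatter. Also open is whether the 4-chloro-3-(trifluoromethyl)phenyl group would read the same with methyl in place of hydrogen on the oxygen at the far end of the molecule, and the chloro that stayed in place has no exchange of its own among these compounds.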